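The source may hold more compounds than are shown below. What is called first, only, known or untested is meant among the compounds shown, and "the series" means these compounds.

Measured in an assay (Cavia porcellus) for inhibition of Polyunsaturated fatty acid 5-lipoxygenase (Homo sapiens); on this read-out higher numbers stand for weaker inhibition and lower numbers for stronger inhibition:
compound 1, `NC(=O)N(O)CC1=Cc2cc(OCC3CCCCC3)ccc2OC1`, gives 1390 nM
compound 2, `CC(C)NC(=O)N(O)CC1=Cc2cc(Oc3ccccc3)ccc2OC1`, gives 63 nM

For the measured compounds named here, of the two numbers so far, compound 2 stands lowest. Its nearest neighbour is compound 1, whose value lies above it by a gap beyond the usual scatter, so compound 2 is the stronger inhibitor of the pair. Going by the values given here, compound 1 and compound 2 differ in more than one place, and no step between them is counted, so their two values show only that ordering and nothing about any single change.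

Compound 3 is `O=C(NCc1ccccc1)N(O)CC1=Cc2cc(Oc3ccccc3)ccc2OC1`. It arises from compound 2 by the change (benzyl in place of isopropyl on an amide-type nitrogen), that is, benzyl in place of isopropyl on an amide-type nitrogen, the same difference reading isopropylcarbamoyl to benzylcarbamoyl. The rest of compound 2 is kept. Among the compounds with values here, no measured pair shows this change, so nothing in the data fixes its size or direction. Compound 3 is therefore expected to stay close to compound 2, with a step of a 1.3-fold higher number from compound 2 to compound 3 (0.10 log units; within the scatter) expected to lie within the scatter or only a little beyond it, in either direction. Compound 3 is estimated at 80 nM, within 25 nM to 250 nM.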

Compound 3, half-maximal inhibitory concentration: 440 nM
Beside the measured number, compound 3's estimate is 5.5-fold (0.74 log units) below it; the whole stated range lies below it.
By their numbers in this assay, from the lowest: compound 2; then compound 3; then compound 1.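

Placing benzyl in place of isopropyl on an amide-type nitrogen whose other neighbour is the carbonyl carbon gives, in this assay, a 7.0-fold higher number from compound 2 to compound 3 (0.84 log units; beyond the scatter), so inhibition weakens with the rest of compound 2 kept. For the compounds shown here, this is the first step that can be read at this position, and it shows that the group on this nitrogen matters: exchanging isopropyl, with 3 heavy atoms and no ring, for benzyl, with 7 heavy atoms and one six-membered aromatic ring, moves the value beyond the usual scatter. Nothing available bears on why this step goes in this direction or has this size.

A single step cannot separate the contribution of the added carbons from that of the aromatic ring, and a cyclohexylmethyl, phenethyl or tert-butyl group on this nitrogen would help to tell these apart. On these data alone, it also remains open whether the same exchange would give a similar step with the cyclohexylmethoxy group of compound 1 in place of the phenoxy group of compound 2.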